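Swapping trifluoromethyl for hydroxy on compound 3

The compounds below may be only part of what the source reports. "The series", "measured", "known", "first", "only" and "open" are said of these compounds alone.

Of the compounds shown here, three sharing one core have been measured in an ADME assay for permeability, using PAMPA, with a stated time of 3 h; a higher number here means that the compound crosses the layer faster, a lower number that the compound crosses the layer more slowly. Compound 1 `O=C(Nc1cccc([N+](=O)[O-])c1)c1cc(Cl)ccc1O`, with a nitro group, gives 19.5 10^-6 cm/s. Compound 2 `O=C(Nc1cccc(Cl)c1)c1cc(Cl)ccc1O`, with chloro, gives 8.6 10^-6 cm/s. Compound 3 `O=C(Nc1cccc(C(F)(F)F)c1)c1cc(Cl)ccc1O`, with trifluoromethyl, gives 4.2 10^-6 cm/s, the lowest of the three. The next compound, compound 4 `O=C(Nc1cccc(O)c1)c1cc(Cl)ccc1O`, has hydroxy in place of trifluoromethyl on an aromatic carbon.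

Among the compounds with values here, no measured step brings in hydroxy, so the closest guides are the two steps in which trifluoromethyl enters: a 4.6-fold lower number from compound 1 to compound 3 (0.67 log units; beyond the scatter) and a 2.0-fold lower number from compound 2 to compound 3 (0.31 log units; beyond the scatter). Both are modest but beyond the scatter, and so is a 2.3-fold lower number from compound 1 to compound 2 (0.36 log units; beyond the scatter). As far as these compounds go, each of the other two groups thus stands higher than trifluoromethyl, which suggests that compound 4 may also stand higher, although the direction remains untested for hydroxy. The expected change is a 1.9-fold higher number from compound 3 to compound 4 (0.28 log units; within the scatter), a modest rise close to the smaller of those two steps. Compound 4 is estimated at 8 10^-6 cm/s, with an expected range from 3 10^-6 cm/s to 20 10^-6 cm/s.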

Compound 4, apparent permeability: 15.9 10^-6 cm/s
Beside the measured number, compound 4's estimate is 2.0-fold (0.30 log units) below it; the range from low to high includes it.
By their numbers in this assay, from the lowest: compound 3; then compounds 2, 4 and 1 (each within the scatter of the next, the first and the last beyond it).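

In this assay, hydroxy in place of trifluoromethyl gives a 3.8-fold higher number from compound 3 to compound 4 (0.58 log units; beyond the scatter) and so moves this position upward, which shows that the trifluoromethyl compound stays apart from hydroxy as well as from nitro and chloro. Compound 4 does not separate from the other two groups, since hydroxy in place of chloro gives a 1.8-fold higher number from compound 2 to compound 4 (0.27 log units; within the scatter) and hydroxy in place of nitro gives a 1.2-fold lower number from compound 1 to compound 4 (0.09 log units; within the scatter) even though compound 1 and compound 2 themselves differ beyond the scatter. The data offer no measured basis for explaining these differences.

The compounds shown leave open whether an amine or a carboxylic acid on this aromatic carbon would stand with hydroxy or with trifluoromethyl. They also leave open whether the low place of trifluoromethyl would persist on a different core.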